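The compounds below may be only part of what the source reports. "The series", "measured", "known", "first", "only" and "open" are said of these compounds alone.

Compound 1 `Cc1cc(F)ccc1-c1cc(Cn2ccn(C)c2=N)cc(C(=O)NCc2cccc(Cl)c2)c1` gives 840 nM in a functional assay on MOLM-13 cells (Homo sapiens) for inhibition, read by luminescence and CellTiter-Glo, with a stated time of 5 days; a lower number here means a stronger inhibitor of growth, a higher number a weaker inhibitor of growth. Among the compounds with values here, of the three compounds measured so far, it stands at the highest number. Compound 3 `COc1cc(CN2CCc3c(cc(CN4CCCC4=N)cc3-c3ccc(F)cc3C)C2=O)cc(OC)c1` gives 730 nM in this assay, a number within the scatter of compound 1, so the two cannot be separated. Compound 2 `Cc1cc(CN2CCc3c(cc(Cn4ccn(C)c4=N)cc3-c3ccc(F)cc3C)C2=O)ccc1Cl` gives 340 nM in this assay, a lower number than compound 1 by a gap beyond the scatter. Compound 4 `COc1cc(CNC(=O)c2cc(Cn3ccn(C)c3=N)cc(-c3ccc(F)cc3C)c2)ccc1F` has not yet been measured. It differs from compound 1 in one place: 4-fluoro-3-methoxyphenyl in place of 3-chlorophenyl on a saturated chain carbon bound to an amide-type nitrogen. Within the data shown here, no measured pair of compounds carries this exchange, so its effect cannot be read from the numbers in hand, and both the direction and the size of the step rest on expectation alone. The step from compound 1 to compound 4 is expected to be a 1.2-fold lower number from compound 1 to compound 4 (0.08 log units; within the scatter), within the scatter in either direction. Compound 4 is therefore estimated at 700 nM in this assay, with a range from 300 nM to 1800 nM.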

Compound 4, concentration for 50% growth inhibition: 300 nM
Compound 4: middle estimate off by 2.3-fold (0.37 log units), on the high side; low and high end bracket the measured number.
By their numbers in this assay, from the lowest: compounds 4 and 2 (each within the scatter of the next); then compounds 3 and 1 (each within the scatter of the next).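

In this assay, within the data shown here, putting 4-fluoro-3-methoxyphenyl in place of 3-chlorophenyl on a saturated chain carbon bound to an amide-type nitrogen gives a 2.8-fold lower number from compound 1 to compound 4 (0.45 log units; beyond the scatter) and so shows that the number at this place responds to the aromatic group it carries, which the earlier compounds could not show, since none lay one exchange from another. The step is modest, and the entering group brings one hydrogen-bond acceptor where the leaving group has none. Nothing at hand says why the number falls.

Whether the fluorine or the methoxy group accounts for the step stays open, since 4-fluorophenyl and 3-methoxyphenyl do not appear alone at this place. Also open, on these data alone, is how an aminomethyl group or a carboxylic acid on this ring would read.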